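Hydroxy to amino on the pendant ring: two cores compared

A few compounds are considered here, and "the series" means these few. Any claim that something is new, unique, unknown or untested is made for them only; others in the source may bear on it.

In a functional assay on MCF7 cells (Homo sapiens) for cytotoxicity, read by MTT assay, with a stated time of 3 days (a lower number here means a stronger inhibitor, a higher number a weaker inhibitor), compound 1 `COc1ccc(-c2cccc(O)c2)c(OC)c1` gives 50.2 ug/mL. Its counterpart compound 2 `COc1ccc(-c2cccc(N)c2)c(OC)c1` carries the change amino in place of hydroxy on an aromatic carbon and returns only a limit, > 100 ug/mL, in this assay. The measured step is therefore an at least 1.9-fold higher number from compound 1 to compound 2 (0.29 log units; that floor lies within the scatter), and its floor is set by the limit of > 100 ug/mL in this assay, at which 1 of the 3 values shown sits. Compound 3 `COc1ccc(-c2cccc(O)c2)cc1OC` has the same atoms as compound 1 joined differently; the difference between the two cores is not broken down here. In this assay compound 3 gives 48 ug/mL, within the scatter of compound 1. Compound 4 `COc1ccc(-c2cccc(N)c2)cc1OC` differs from compound 3 by amino in place of hydroxy on an aromatic carbon, the same kind of change, with the same place wording. The step of a 2.3-fold higher number from compound 3 to compound 4 (0.36 log units; beyond the scatter) is expected for compound 4, resting on an at least 1.9-fold higher number from compound 1 to compound 2 (0.29 log units; that floor lies within the scatter). Compound 4 is thus estimated at 110 ug/mL in this assay, and a limit rather than a number is likely.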

Compound 4, half-maximal inhibitory concentration: > 100 ug/mL
Compound 4: a limit, no number; the forecaster's own chance of this, stated with the estimate: 65%; the middle value lies beyond the limit too.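

In this assay compound 4 returns a limit, > 100 ug/mL, and not a number. Amino in place of hydroxy on an aromatic carbon gives an at least 2.0-fold higher number from compound 3 to compound 4 (0.31 log units; beyond the scatter), which is only a floor, and it compares with the step on the core of compound 1 as follows: the same change on two cores in this assay, an at least 1.9-fold higher number (0.29 log units; that floor lies within the scatter) from compound 1 to compound 2 and an at least 2.0-fold higher number (0.31 log units; beyond the scatter) from compound 3 to compound 4; the limit leaves it open whether they differ. From the compounds shown here alone, the two cores agree in that neither amino compound gives a number, while the true size of the step on either core stays unknown: the limit of > 100 ug/mL in this assay, at which 2 of the 4 values shown sit.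

The compounds shown leave open whether another group in the same place, such as a carboxylic acid, an acetamide or a fluorine, would keep the numbers of the hydroxy compounds. Also open, going by these compounds, is whether the two cores would differ with such a group.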